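Branched hydroxy-acyl esters on the shared core: compound 4

The source may report more compounds than this note shows. Statements on the series, on what has been measured and on what is new or still open speak of the compounds shown alone.

Measured so far in a functional assay on DU-145 cells (Homo sapiens) for cytotoxicity, read by MTT assay; a higher number here means a weaker inhibitor, a lower number a stronger inhibitor:
compound 1, `CCC(C)(O)CC(=O)O[C@H](CC=C(C)C)C1=CC(=O)c2c(O)ccc(O)c2C1=O`, 16000 nM
compound 2, `CC(C)=CC[C@@H](OC[C@@H](C)O)C1=CC(=O)c2c(O)ccc(O)c2C1=O`, 14300 nM
compound 3, `CC(C)=CC[C@@H](OC(=O)CCO)C1=CC(=O)c2c(O)ccc(O)c2C1=O`, 55300 nM

Compound 3 stands at the highest number of the three. The step from compound 1 is a 3.5-fold higher number from compound 1 to compound 3 (0.54 log units; beyond the scatter) and the step from compound 2 is a 3.9-fold higher number from compound 2 to compound 3 (0.59 log units; beyond the scatter), both beyond the scatter. Compound 1 and compound 2 cannot be ordered against each other, as a 1.1-fold lower number from compound 1 to compound 2 (0.05 log units; within the scatter) lies within the scatter.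

Compound 4, `CCC(O)(CC)CC(=O)O[C@H](CC=C(C)C)C1=CC(=O)c2c(O)ccc(O)c2C1=O`, differs from compound 3 by 1-ethyl-1-hydroxypropyl in place of hydroxymethyl on a saturated chain carbon bound to a carbonyl carbon. Among the compounds with values here, the one measured step that bears on this change is the step from compound 1 to compound 3, where hydroxymethyl replaced 1-hydroxy-1-methylpropyl at the same place and the number rose by a 3.5-fold higher number from compound 1 to compound 3 (0.54 log units; beyond the scatter). Within the data shown here, compound 4 carries 1-ethyl-1-hydroxypropyl at that place, which goes one carbon past compound 1; no measured pair shows what that further carbon does, so the expectation rests on reversing the step from compound 1 to compound 3. Compound 4 is therefore expected to fall back to about the level of compound 1, a downward step of a 3.7-fold lower number from compound 3 to compound 4 (0.57 log units; beyond the scatter). The estimate for compound 4 in this assay is 15000 nM, with a range from 7000 nM to 35000 nM.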

Compound 4, half-maximal inhibitory concentration: 67000 nM
Compound 4: middle estimate off by 4.5-fold (0.65 log units), on the low side, outside the stated range (above it).
By their numbers in this assay, from the lowest: compounds 2 and 1 (each within the scatter of the next); then compounds 3 and 4 (each within the scatter of the next).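

In this assay, the place on a saturated chain carbon bound to a carbonyl carbon does not separate 1-ethyl-1-hydroxypropyl from hydroxymethyl: a 1.2-fold higher number from compound 3 to compound 4 (0.08 log units; within the scatter) marks no readable change between these two groups. Yet methyl in place of hydrogen on a saturated chain carbon, two bonds along the chain from an oxygen on a saturated carbon, gives a 4.2-fold higher number from compound 1 to compound 4 (0.62 log units; beyond the scatter), so no steady order runs from hydroxymethyl through 1-hydroxy-1-methylpropyl to 1-ethyl-1-hydroxypropyl, and compound 1 stands apart from both compound 3 and compound 4. Compound 4 also separates from the ether compound, with a 4.7-fold higher number from compound 2 to compound 4 (0.67 log units; beyond the scatter), which leaves compound 1 and compound 2 together at the lower numbers and compound 3 and compound 4 together at the higher ones.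

The data offer no explanation for why this one added methyl separates compound 1 from compound 4. Still open, on these data alone, is how this place would read with an amine or a carboxylic acid in place of the hydroxyl, or with a longer chain such as 1-hydroxy-1-propylbutyl.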